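Notes on replacing the sulfonyl aryl of compound 1

The compounds below may be only part of what the source reports. "The series", "measured", "known", "first", "only" and "open" are said of these compounds alone.

Measured in a functional assay on DU-145 cells (Homo sapiens) for inhibition, read by trypan blue exclusion, with a stated time of 72 h; on this read-out higher numbers stand for weaker inhibition and lower numbers for stronger inhibition:
- compound 1 `Cn1c(=O)c(S(=O)(=O)c2ccc(Cl)cc2Cl)cc2cnc(Nc3ccc4[nH]ccc4c3)nc21`: 1000 nM
- compound 2 `COc1ccc(Nc2ncc3cc(S(=O)(=O)c4ccc(C)cc4)c(=O)n(C)c3n2)cc1`: 100000 nM
- compound 3 `CN1CCN(c2ccc(Nc3ncc4cc(S(=O)(=O)c5ccc(F)cc5F)c(=O)n(C)c4n3)cc2)CC1`: 5000 nM

Compound 1 has the lowest number of the three, and both compound 3 and compound 2 lie beyond the scatter from it.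

Compound 4 `COc1ccc(S(=O)(=O)c2cc3cnc(Nc4ccc5[nH]ccc5c4)nc3n(C)c2=O)cc1` has not yet been measured in this assay. It differs from compound 1 in one place: 4-methoxyphenyl in place of 2,4-dichlorophenyl on a sulfonyl sulfur. Among the compounds with values here, no measured pair isolates this change, so the evidence is indirect. Within the data shown here, compound 2, the only measured compound without chlorine or fluorine, gives 100000 nM, but it also differs from compound 4 elsewhere, so this comparison is loose. The expected change is a 4.0-fold higher number from compound 1 to compound 4 (0.60 log units; beyond the scatter), towards a higher number and weaker inhibition, beyond the scatter. Compound 4 is estimated at 4000 nM, with an expected range of 800 nM to 30000 nM.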

Compound 4, half-maximal inhibitory concentration: 500 nM
The estimate for compound 4 lay 8.0-fold (0.90 log units) above the measured number; measured number outside the range, below it.
By their numbers in this assay, from the lowest: compounds 4 and 1 (each within the scatter of the next); then compound 3; then compound 2.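

With the rest of compound 1 held constant, the sulfonyl aryl in this assay can now be read directly, and the change gives a 2.0-fold lower number from compound 1 to compound 4 (0.30 log units; within the scatter). On this core, 4-methoxyphenyl and 2,4-dichlorophenyl on a sulfonyl sulfur are therefore not told apart, so chlorine on this aryl is not required for a number at the level of compound 1. Nothing available bears on why the two groups read alike.

Still open, as far as these compounds go, is how this position responds to an aryl carrying a carboxylic acid or a primary amine, or to a saturated ring such as cyclohexyl in place of the aryl. It is also open whether the two groups would still read alike on a different core, as no pair shown compares them on a second one.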